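Trading Dimethylamino for Methoxy on the Shared Core

A few compounds are considered here, and "the series" means these few. Any claim that something is new, unique, unknown or untested is made for them only; others in the source may bear on it.

Compound 3 `CCCCC1(CCCC)CS(=O)(=O)c2ccc(N(C)C)cc2[C@@H](c2ccc(F)cc2)[C@H]1O` stands second highest of the three numbers obtained in an assay on cells for inhibition of ileal sodium/bile acid cotransporter (Homo sapiens) (on this read-out lower numbers stand for stronger inhibition and higher numbers for weaker inhibition), where compound 3 gives 10 nM. Compound 2 `CCCCC1(CCCC)CS(=O)(=O)c2ccc(N(C)C)cc2[C@@H](c2ccc(OC)cc2)[C@H]1O` gives 7 nM in this assay. The step of a 1.4-fold higher number from compound 2 to compound 3 (0.15 log units; within the scatter) lies within the scatter. Compound 1 `CCCCC1(CCCC)CS(=O)(=O)c2ccc(C)cc2[C@@H](c2ccc(F)cc2)[C@H]1O` gives 46 nM in this assay. Among the compounds with values here, the step of a 4.6-fold lower number from compound 1 to compound 3 (0.66 log units; beyond the scatter) is the only measured change at the aromatic carbon in question. Compound 4 `CCCCC1(CCCC)CS(=O)(=O)c2ccc(OC)cc2[C@@H](c2ccc(F)cc2)[C@H]1O` differs from compound 3 by methoxy in place of dimethylamino on an aromatic carbon. Within the data shown here, no measured step involves methoxy at that place, so only the single modest step seen there offers guidance. A modest move toward higher numbers in this assay is therefore expected, a 2.0-fold higher number from compound 3 to compound 4 (0.30 log units; within the scatter). Compound 4 is estimated at 20 nM, with a range from 8 nM to 50 nM.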

Compound 4, half-maximal inhibitory concentration: 50 nM
Compound 4: the middle estimate sits 2.5-fold (0.40 log units) below what was measured, within the range that was stated.
By their numbers in this assay, from the lowest: compounds 2 and 3 (each within the scatter of the next); then compounds 1 and 4 (each within the scatter of the next).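

Methoxy at this aromatic carbon gives a 5.0-fold higher number from compound 3 to compound 4 (0.70 log units; beyond the scatter) in this assay and so loses the low number seen with dimethylamino. Set against methyl, methoxy gives a 1.1-fold higher number from compound 1 to compound 4 (0.04 log units; within the scatter) and the two cannot be told apart here, which leaves dimethylamino alone among these three groups in holding the low number.

As far as these compounds go, whether another amine, such as diethylamino or a pyrrolidine ring, would also hold that low number remains open. Nothing measured here explains why dimethylamino differs from methoxy and methyl.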